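Adding hydroxymethyl arms to the diol ether chain

The source may hold more compounds than are shown below. What is called first, only, known or untested is meant among the compounds shown, and "the series" means these compounds.

In an ADME assay on S9 fraction from liver (Mus musculus, strain CD-1) for metabolic stability, read by LC-MS, using NADPH, with stated times of 5 min and 60 min, tested at 5 uM (a higher number here means that more of the compound is left, a lower number that less of the compound is left), compound 3 (`COc1cc(C2CN(C(=O)c3cc(COC[C@H](O)CO)ccn3)C2)ccc1OCc1ccc(C2CC2)cc1`) gives 70% and sits within the scatter of compound 1 (`COc1cc(C2CN(C(=O)c3cc(OCCO)ccn3)C2)ccc1OCc1ccc(C2CC2)cc1`), which gives 64% as its reading. Compound 2 (`COc1cc(C2CN(C(=O)c3cc(OCCCC(=O)O)ccn3)C2)ccc1OCc1ccc(C2CC2)cc1`) gives 88% and stands apart, with a number 18 percentage points lower from compound 2 to compound 3 (beyond the scatter) as the modest step.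

For the measured compounds named here, compound 4 (`COc1cc(C2CN(C(=O)c3cc(COCC(CO)(CO)CO)ccn3)C2)ccc1OCc1ccc(C2CC2)cc1`) carries 2-hydroxy-1,1-bis(hydroxymethyl)ethyl in place of 1,2-dihydroxyethyl on a saturated chain carbon bound to an oxygen on a saturated carbon as its only change: 2-hydroxy-1,1-bis(hydroxymethyl)ethyl in place of 1,2-dihydroxyethyl. Going by the values given here, the closest precedent is a number 6 percentage points higher from compound 1 to compound 3 (within the scatter) between two neutral hydroxylated chains. Compound 2 carries a carboxylic acid chain, so a number 24 percentage points higher from compound 1 to compound 2 (beyond the scatter) bears less directly. No change beyond the scatter is expected, and the estimate is a number 2 percentage points higher from compound 3 to compound 4 (within the scatter) as the step. For compound 4 the estimated value is 72% with an expected range from 58% to 86% in this read-out.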

Compound 4, percent of the compound remaining: 81%
Estimate against measurement, compound 4: 9 percentage points below; measured number inside the range.
By their numbers in this assay, from the lowest: compounds 1 and 3 (each within the scatter of the next); then compounds 4 and 2 (each within the scatter of the next).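

In this assay the larger neutral chain moves the number at this position: 2-hydroxy-1,1-bis(hydroxymethyl)ethyl in place of 1,2-dihydroxyethyl gives a number 11 percentage points higher from compound 3 to compound 4 (beyond the scatter) and so goes beyond the scatter, which the earlier swap between neutral hydroxylated chains did not. The same chain gives a number 17 percentage points higher from compound 1 to compound 4 (beyond the scatter) against 2-hydroxyethoxy and a number 7 percentage points lower from compound 2 to compound 4 (within the scatter) against 3-carboxypropoxy, so a chain with no net charge matches the acid-bearing chain within the scatter. Nothing measured here accounts for these steps. Open, on these data alone, is whether an amine, or a longer chain carrying the same hydroxymethyl arms, would keep this number.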